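Moving the hydroxyl within a triaryl pyridine series

The compounds below may be only part of what the source reports. "The series", "measured", "known", "first", "only" and "open" are said of these compounds alone.

Three compounds share one core. Compound 1 `Oc1ccc(-c2cc(-c3ccccn3)nc(-c3ccccc3Cl)c2)cc1` and compound 3 `Oc1ccc(-c2cc(-c3ccncc3)nc(-c3ccccc3Cl)c2)cc1` carry pyridyl rings but have no result recorded in a functional assay on HCT-15 cells (Homo sapiens) for cytotoxicity, read by CCK-8 assay and cell counting, with a stated time of 2 days; a lower number here means a stronger inhibitor, a higher number a weaker inhibitor: for compound 1 the entry reads "not determined" (no result reported), and for compound 3 the entry reads "not determined" (no result reported). For the measured compounds named here, compound 2 `Oc1ccc(-c2cc(-c3cccs3)nc(-c3ccccc3Cl)c2)cc1` is therefore the only member with a number: in this assay compound 2 gives 5430 nM, so it stands alone, with nothing to compare against. Compound 4 `Oc1cccc(-c2cc(-c3cccs3)nc(-c3ccccc3Cl)c2)c1` is the next entry, not yet measured. It differs from compound 2 by 3-hydroxyphenyl in place of 4-hydroxyphenyl on an aromatic carbon. Going by the values given here, no pair of measured compounds shows this kind of change, so no step size is known. In the absence of such a step, the change is expected to move the value little, if at all, beyond the usual scatter; the expected step is a 1.1-fold higher number from compound 2 to compound 4 (0.04 log units; within the scatter). In this assay compound 4 is therefore estimated at 6000 nM, with a range from 2500 nM to 15000 nM.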

Compound 4, half-maximal inhibitory concentration: 2790 nM
For compound 4 the middle estimate is 2.2-fold (0.33 log units) above the measured one; low and high end bracket the measured number.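

Placing the hydroxyl as 3-hydroxyphenyl rather than 4-hydroxyphenyl, on the carbon opposite the ring nitrogen, gives the first readable step in this assay: a 1.9-fold lower number from compound 2 to compound 4 (0.29 log units; within the scatter). With the thiophen-2-yl and 2-chlorophenyl groups unaltered, the two hydroxyl placements cannot be told apart in this assay. Nothing available explains this result.

The compounds shown leave open whether an amine or a methoxy group in place of the hydroxyl would give a step beyond the scatter. Any step involving compound 1 or compound 3 cannot be read.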